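A few compounds are considered here, and "the series" means these few. Any claim that something is new, unique, unknown or untested is made for them only; others in the source may bear on it.

Compound 2, with the structure `O=C(Nc1ccncc1)Nc1ccccc1OCc1ccccc1`, is the starting point. In a functional assay on the whole organism with Mus musculus as the target, in the maximal electroshock model, with a stated time of 30 min (a lower number here means that less compound is needed, a higher number that more compound is needed for the effect), compound 2 gives > 300 mg/kg, which is a limit of the assay rather than a measured number. Among the compounds with values here, compound 1, with the structure `N#Cc1ccccc1NC(=O)Nc1ccncc1`, is the only other compound measured here. In this assay compound 1 gives > 300 mg/kg, again a limit and not a number. Within the data shown here, the one step between measured compounds, a step that the two limits leave unreadable from compound 1 to compound 2, therefore has no readable size, and the whole picture is the limit of > 300 mg/kg in this assay, at which 2 of the 2 values shown sit.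

Compound 3 has the structure `Nc1ccccc1NC(=O)Nc1ccncc1`. It differs from compound 2 in one place: amino in place of benzyloxy on an aromatic carbon. Among the measured compounds shown here, no measured step bears on this change, and the limit on compound 2 gives no direction for it, so the step that the limit leaves unreadable from compound 2 to compound 3 is only an expectation, and most likely the assay will again stop at its limit. For compound 3 the estimate in this assay is 400 mg/kg, with a range from 150 mg/kg to 1000 mg/kg.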

Compound 3, minimum effective dose: > 300 mg/kg
Compound 3 gave a limit, no number (the forecaster's own chance of this, stated with the estimate: 75%); the middle value does not contradict the limit.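

In this assay, within the data shown here, compound 3 gives > 300 mg/kg, again a limit of the assay and not a number, so no step from compound 1 or compound 2 to compound 3 can be read. The compounds shown leave open whether any group at this place would give a readable dose: the limit of > 300 mg/kg in this assay, at which 3 of the 3 values shown sit.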